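Replacing the 3-amino-1H-indazol-6-yl group of compound 2

A few compounds are considered here, and "the series" means these few. Any claim that something is new, unique, unknown or untested is made for them only; others in the source may bear on it.

In a functional assay on K562 cells (Homo sapiens) for inhibition, read by MTT assay, with a stated time of 48 h (a higher number here means a weaker inhibitor, a lower number a stronger inhibitor), compound 1 `CC(C)(C)OC(=O)N1C[C@@H](n2cc(-c3ccc4c(N)n[nH]c4c3)nn2)C[C@H]1C(=O)Nc1ccc(Cl)cc1Cl` gives 12200 nM, compound 2 `CC(C)(C)OC(=O)N1C[C@@H](n2cc(-c3ccc4c(N)n[nH]c4c3)nn2)C[C@H]1C(=O)Nc1ccc(Br)cc1` gives 3710 nM and compound 3 `Nc1n[nH]c2cc(-c3cn([C@@H]4CN[C@H](C(=O)Nc5ccc(Br)cc5)C4)nn3)ccc12` gives 10300 nM. Compound 2 therefore holds the lowest of the three numbers, and both other compounds lie beyond the scatter from it.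

Compound 4 `CC(C)(C)OC(=O)N1C[C@@H](n2cc(-c3ccc4nc(N)sc4n3)nn2)C[C@H]1C(=O)Nc1ccc(Br)cc1` keeps the rest of compound 2 and alters only the group on an aromatic carbon of the five-membered aromatic ring with 3 nitrogen: a group of 10 heavy atoms (6 carbon, 3 nitrogen, 1 sulfur; one five-membered aromatic ring with 2 hetero atoms, one six-membered aromatic ring with 1 hetero atom) in place of a group of 10 heavy atoms (7 carbon, 3 nitrogen; one five-membered aromatic ring with 2 hetero atoms, one six-membered aromatic ring of carbon only), on an aromatic carbon.

Neither measured step touches this place. The first, a 3.3-fold lower number from compound 1 to compound 2 (0.52 log units; beyond the scatter), came with 4-bromophenyl in place of 2,4-dichlorophenyl. The second, a 2.8-fold higher number from compound 2 to compound 3 (0.44 log units; beyond the scatter), came with hydrogen in place of tert-butoxycarbonyl. Both were modest, so they serve only as a gauge of how far one change has moved the numbers in this small set. Going by the values given here, no measured compound carries the entering group, and the data give no direct direction for the change. Compound 2 sits at the low end with 3710 nM, so a modest rise is expected rather than a fall. The expected change is a 2.2-fold higher number from compound 2 to compound 4 (0.33 log units; beyond the scatter), and it remains uncertain. Compound 4 is estimated at 8000 nM, with an expected range from 2500 nM to 25000 nM.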

Compound 4, half-maximal inhibitory concentration: 29200 nM
Compound 4: the middle estimate sits 3.7-fold (0.56 log units) below what was measured, and the stated range ends below it.
By their numbers in this assay, from the lowest: compound 2; then compounds 3 and 1 (each within the scatter of the next); then compound 4.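

In this assay the group on an aromatic carbon of the five-membered aromatic ring with 3 nitrogen proves to matter, and exchanging 3-amino-1H-indazol-6-yl for the sulfur-containing group gave a 7.9-fold higher number from compound 2 to compound 4 (0.90 log units; beyond the scatter). The heavy-atom count stays the same across this change, so that count alone does not settle the outcome at this position; what differs is the atom make-up of the two rings and the counts of hydrogen-bond donors and acceptors, and this single pair cannot separate those differences from one another. Nothing available bears on why the number rose at this position.

The compounds shown leave open which part of the 3-amino-1H-indazol-6-yl group carries the difference, for instance whether a simple aminophenyl group or an indazolyl group without its amine would stay close to compound 2 or move toward compound 4. They also leave open whether the same exchange would give a step of similar size in the presence of 2,4-dichlorophenyl on the amide nitrogen, or with hydrogen in place of tert-butoxycarbonyl on the ring nitrogen.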